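A few compounds are considered here, and "the series" means these few. Any claim that something is new, unique, unknown or untested is made for them only; others in the source may bear on it.

In a functional assay on MCF7 cells (Homo sapiens) for cytotoxicity, read by MTT assay, with a stated time of 24 h (a lower number here means a stronger inhibitor, a higher number a weaker inhibitor), compound 1 `Cc1ccc2oc(SCC(=O)Nc3ccc(-c4nc(-c5ccccc5)c(-c5ccccc5)n4C)cc3)nc2c1` gives 22.4 ug/mL, compound 2 `Cn1nnnc1SCC(=O)Nc1ccc(-c2nc(-c3ccccc3)c(-c3ccccc3)n2C)cc1` gives 4.5 ug/mL and compound 3 `Cn1c(-c2ccc(NC(=O)CSC3=NCCS3)cc2)nc(-c2ccccc2)c1-c1ccccc1` gives 26.7 ug/mL. Compound 3 therefore sits at the high end of these numbers, level with compound 1: a 1.2-fold higher number from compound 1 to compound 3 (0.08 log units; within the scatter) stays within the scatter, while a 5.9-fold higher number from compound 2 to compound 3 (0.77 log units; beyond the scatter) lies beyond it.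

Compound 4 `CN(C)/C=C/N1CCN(CC(=O)Nc2ccc(-c3nc(-c4ccccc4)c(-c4ccccc4)n3C)cc2)CC1` carries the next change: a group of 11 heavy atoms (8 carbon, 3 nitrogen; one six-membered non-aromatic ring with 2 hetero atoms) in place of a group of 6 heavy atoms (3 carbon, 1 nitrogen, 2 sulfur; one five-membered non-aromatic ring with 2 hetero atoms), on a saturated chain carbon bound to a carbonyl carbon. Among the compounds with values here, no measured step exchanges a group at this place, since all three exchange a group on a sulfur, so they bear on it only indirectly. Two of them are modest, a 5.0-fold lower number from compound 1 to compound 2 (0.70 log units; beyond the scatter) and a 5.9-fold higher number from compound 2 to compound 3 (0.77 log units; beyond the scatter), and the third, a 1.2-fold higher number from compound 1 to compound 3 (0.08 log units; within the scatter), is within the scatter. The numbers do not follow group size across compound 1, compound 2 and compound 3, and the steps run in both directions.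

A change at this place in this assay could thus be modest or lie within the scatter, and the data give no firm direction. The middle of the measured numbers is the most defensible guide. The estimated step is a 1.9-fold lower number from compound 3 to compound 4 (0.28 log units; within the scatter), small and with its direction uncertain. For compound 4 the estimated value is 14 ug/mL, with an expected range of 4 ug/mL to 40 ug/mL.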

Compound 4, half-maximal inhibitory concentration: 80 ug/mL
For compound 4 the middle estimate is 5.7-fold (0.76 log units) below the measured one, and the stated range ends below it.
By their numbers in this assay, from the lowest: compound 2; then compounds 1 and 3 (each within the scatter of the next); then compound 4.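

In this assay the exchange on the saturated chain carbon bound to a carbonyl carbon goes one way against all three sulfur-linked compounds: a 3.0-fold higher number from compound 3 to compound 4 (0.48 log units; beyond the scatter) and a 3.6-fold higher number from compound 1 to compound 4 (0.55 log units; beyond the scatter) are modest, and an 18-fold higher number from compound 2 to compound 4 (1.25 log units; beyond the scatter) is large. The earlier steps shown here, all among groups on a sulfur, ran in both directions, whereas compound 4, the only one here with 4-(2-(dimethylamino)ethenyl)piperazin-1-yl in place of a sulfur-linked group, has the highest number, with its steps from all three others beyond the scatter. The size of the rise depends on the group that leaves, and it is greatest when (1-methyl-1H-tetrazol-5-yl)sulfanyl is the group replaced.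

No available measurement accounts for the rise. Still open, from the compounds shown here alone, is whether it follows the loss of the sulfur link, the piperazine ring or the dimethylaminoethenyl chain, a question that an unsubstituted piperazine, a morpholine or a simple dimethylamino group on the same chain carbon would help to separate.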